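Series notes: ring-nitrogen aryl swap ahead of measurement

A few compounds are considered here, and "the series" means these few. Any claim that something is new, unique, unknown or untested is made for them only; others in the source may bear on it.

Measured compounds:
- compound 1 `CCOC(=O)C1=C(C)N(c2ccc(Br)cc2)C=CC1c1ccccc1`: -35.7%
- compound 2 `COC(=O)C1=C(C)N(c2ccc(OC)cc2)C=C(C)C1c1ccccc1`: -22.6%

Both numbers come from a functional assay, tested at 200 ug/mL; on this read-out higher numbers stand for a weaker effect at the one concentration tested and lower numbers for a stronger effect. Compound 2 gives the higher of the two readings, and its gap to compound 1 lies beyond the scatter, so the two compounds are distinguishable on this assay. Among the compounds with values here, no pair of measured compounds differs in a single place, so no measured step is available to calibrate the change now under consideration.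

Compound 3 `COC(=O)C1=C(C)N(c2cccc(C)c2C)C=C(C)C1c1ccccc1` is the next compound for this assay. Its difference from compound 2 is 2,3-dimethylphenyl in place of 4-methoxyphenyl on an amine nitrogen in a ring.

Within the data shown here, with no comparable measured step in the set, the expectation rests on compound 2 alone, whose reading of -22.6% serves as the anchor. The step of a number 2.6 percentage points higher from compound 2 to compound 3 (within the scatter) is expected to be small, none beyond the scatter. Compound 3 is estimated at -20%, with a range from -45% to 5%.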

Compound 3, a percentage reported as activity, at one concentration (the size of the read-out at that concentration, not a potency): -29.3%
The estimate for compound 3 lay 9.3 percentage points above the measured number; the measured number falls inside the stated range.
By their numbers in this assay, from the lowest: compounds 1, 3 and 2 (each within the scatter of the next, the first and the last beyond it).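

In this assay, within the data shown here, this is the first step that changes one place only: on the amine nitrogen in a ring, 2,3-dimethylphenyl in place of 4-methoxyphenyl gives a number 6.7 percentage points lower from compound 2 to compound 3 (within the scatter) on this read-out. At this position the read-out therefore does not separate these two aryl groups, even though the group that leaves carries a hydrogen-bond acceptor and the group that enters carries none. Nothing at hand offers an explanation for this step.

As far as these compounds go, whether a benzyl or pyridyl group on the same nitrogen would give a step beyond the scatter remains open. So does the effect of a change elsewhere on the shared core, such as a carboxylic acid in place of the methoxycarbonyl group.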